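Swapping 3-ethoxyphenyl for Indolyl: Cytotoxicity Outlook

A few compounds are considered here, and "the series" means these few. Any claim that something is new, unique, unknown or untested is made for them only; others in the source may bear on it.

Compound 1 `CC(=O)c1cccc(-c2ccc(C(=O)N(Cc3cccc(OCCCCCC(=O)O)c3)C(C)C)cc2)c1` gives > 26000 nM in an ADME assay on HepG2 cells (Homo sapiens) for cytotoxicity, read by CellTiter-Glo and resazurin assay, with a stated time of 72 h (a lower number here means that less compound is needed, a higher number that more compound is needed for the effect), a limit of the method rather than a number.
Compound 2 `CC(C)N(Cc1cccc(OCCCCCC(=O)O)c1)C(=O)c1ccc(-c2ccoc2)cc1` gives > 26000 nM in this assay, also a limit.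
Compound 3 `CCOc1cccc(-c2ccc(C(=O)N(Cc3cccc(OCCCCCC(=O)O)c3)C(C)C)cc2)c1` gives > 20800 nM in this assay, again a limit.

Compound 3 therefore stands only at a limit, as do the other two values shown (the limit of > 20800 nM in this assay, at which 1 of the 3 values shown sits, (the limit of > 26000 nM in this assay, at which 2 of the 3 values shown sit)). Compound 4 `CC(C)N(Cc1cccc(OCCCCCC(=O)O)c1)C(=O)c1ccc(-c2ccc3cc[nH]c3c2)cc1` carries 1H-indol-6-yl in place of 3-ethoxyphenyl on an aromatic carbon. Going by the values given here, the steps that bear on this change are a step that the two limits leave unreadable from compound 1 to compound 3 and a step that the two limits leave unreadable from compound 2 to compound 3, both left unreadable by the limits, so no size or direction can be drawn from them. Compound 4 is expected to show no readable change either, with a step that the limit leaves unreadable from compound 3 to compound 4 as the estimated step. The estimate for compound 4 in this assay is 25000 nM, within 8000 nM to 60000 nM.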

Compound 4, half-maximal effective concentration: > 26000 nM
Compound 4 was reported as a limit (the forecaster's own chance of this, stated with the estimate: 80%); middle value at least 1.0-fold (0.01 log units) away from the limit.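

Going by these compounds alone, compound 4, like compounds 1, 2 and 3, is reported only as a limit in this assay, so no step to compound 4 can be read. From the compounds shown here alone, the concentration giving the half-maximal effect stays open for all four compounds.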